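The compounds below may be only part of what the source reports. "The series", "measured", "known", "first", "only" and "open" are said of these compounds alone.

Working notes on the thienopyrimidine-free description of this small series: compound 1 `COc1cc(/C=C/c2nc(Nc3ccc(O)cc3)c3sccc3n2)cc(OC)c1OC` and compound 2 `COc1cc(/C=C/c2nc(NCc3ccc(C)cc3)c3sccc3n2)cc(OC)c1OC` share one core and differ only at the nitrogen on the aromatic ring. In an ADME assay on RAW264.7 cells (Mus musculus) for cytotoxicity, read by MTT assay (on this read-out higher numbers stand for weaker inhibition and lower numbers for stronger inhibition), compound 1 gives > 50000 nM, which is a limit of the assay and not a number. In this assay compound 2 gives > 50000 nM, again a limit of the assay rather than a number. Among the measured compounds shown here, the step that the two limits leave unreadable from compound 1 to compound 2 therefore cannot be read in size, and the only evidence on the measured compounds is the limit of > 50000 nM in this assay, at which 2 of the 2 values shown sit, so compound 2 stands at the limit, with no measured value to place it more exactly.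

The next compound, compound 3 `COc1cc(/C=C/c2nc(NCc3ccncc3)c3sccc3n2)cc(OC)c1OC`, differs from compound 2 in one place: pyridin-4-yl in place of 4-methylphenyl on a saturated chain carbon bound to a nitrogen on an aromatic ring. For the measured compounds named here, the single step recorded so far bears on the same nitrogen but its size is not readable; there is nothing to suggest a move off the limit in either direction beyond the scatter. Compound 3 is therefore expected to sit at a value near the limit, with the estimated step that the limit leaves unreadable from compound 2 to compound 3 being close to none, and the estimate for compound 3 is 60000 nM, in the range 20000 nM to 200000 nM.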

Compound 3, half-maximal inhibitory concentration: > 50000 nM
Compound 3: a limit, no number (the forecaster's own chance of this, stated with the estimate: 75%); the middle value is on the limit's open side.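

Among the compounds shown here, no step among compound 1, compound 2 and compound 3 can be read in this assay, since each gives only a limit of the assay and not a number: the limit of > 50000 nM in this assay, at which 3 of the 3 values shown sit.

The compounds shown leave open whether any change at the nitrogen on the aromatic ring moves the read-out off this limit, and how far.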